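Compound 2 to compound 3: swapping the open chain

The source may hold more compounds than are shown below. What is called first, only, known or untested is meant among the compounds shown, and "the series" means these compounds.

In an ADME assay on Vero 76 cells (Chlorocebus sabaeus) for cytotoxicity, read by crystal violet staining, with a stated time of 96 h (on this read-out higher numbers stand for lower toxicity in this test and lower numbers for higher toxicity in this test), compound 1 `FC(F)(F)c1cccc(NC(=S)Nc2cccc(Br)c2)c1` gives 14000 nM. Compound 2 `C=C(C)CNC(=S)Nc1cccc(C(F)(F)F)c1` gives > 100000 nM, which is a limit of the assay and not a number. Compound 3 `CSCCCNC(=S)Nc1cccc(C(F)(F)F)c1` differs from compound 2 by 2-(methylsulfanyl)ethyl in place of 1-methylethenyl on a saturated chain carbon bound to an amide-type nitrogen, with 2-(methylsulfanyl)ethyl in place of 1-methylethenyl on a saturated chain carbon bound to an amide-type nitrogen. Going by the values given here, the only measured step, an at least 7.1-fold higher number from compound 1 to compound 2 (0.85 log units; beyond the scatter), replaced 3-bromophenyl and offers indirect guidance, as neither group in this change has a ring. The expected step is an at least 1.2-fold lower number from compound 2 to compound 3 (0.09 log units; that floor lies within the scatter), with no change beyond the scatter anticipated. For compound 3, the estimated value is 80000 nM, with an expected range of 30000 nM to 100000 nM.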

Compound 3, half-maximal cytotoxic concentration: > 100000 nM
Compound 3: no number, only a limit; the forecaster's own chance of this, stated with the estimate: 55%; middle value at least 1.2-fold (0.09 log units) away from the limit.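

In this assay 3-(methylsulfanyl)propyl in place of 3-bromophenyl on an amide-type nitrogen gives an at least 7.1-fold higher number from compound 1 to compound 3 (0.85 log units; beyond the scatter) and so repeats, with a second chain without a ring and now carrying sulfur, what 2-methylprop-2-en-1-yl showed. The step between compound 2 and compound 3 cannot be read, since each value is a limit of the assay and not a number: the limit of > 100000 nM in this assay, at which 2 of the 3 values shown sit.

Open, as far as these compounds go, is which change at this place would bring a value inside the readable range. A longer chain, or a chain ending in an amine or a carboxylic acid, would test this.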